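Fluoro to chloro on the benzyl ring of the selenium core

A few compounds are considered here, and "the series" means these few. Any claim that something is new, unique, unknown or untested is made for them only; others in the source may bear on it.

Measured so far:
compound 1 `O=c1c2ccccc2[se]n1-c1nc(SCc2ccc([N+](=O)[O-])cc2)n[nH]1`: 3940 nM
compound 2 `O=c1c2ccccc2[se]n1-c1nc(SCc2ccc(F)cc2)n[nH]1`: > 50000 nM

Compound 2 sits at the weak end of the pair: in a functional assay on HeLa cells (Homo sapiens) for antiproliferative activity, read by CCK-8 assay, with a stated time of 48 h (a higher number here means a weaker inhibitor, a lower number a stronger inhibitor), compound 2 gives only a limit, > 50000 nM, and no number (the limit of > 50000 nM in this assay, at which 1 of the 2 values shown sits). Within the data shown here, compound 1 is the one measured neighbour, and the step of an at least 12-fold higher number from compound 1 to compound 2 (1.10 log units; beyond the scatter) is the only step known so far.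

Compound 3 `O=c1c2ccccc2[se]n1-c1nc(SCc2ccc(Cl)cc2)n[nH]1` differs from compound 2 by chloro in place of fluoro on an aromatic carbon. Among the measured compounds shown here, no measured step covers a swap of one halogen for another; the one known step exchanges nitro for fluoro at the same place and says nothing direct about chloro. The change is small by the count given, so compound 3 is expected to stay close to compound 2, with at best a modest move towards stronger inhibition that may not pass beyond the scatter. For compound 3 the estimate is 40000 nM in this assay, range 12000 nM to 50000 nM, meaning an expected step of an at least 1.2-fold lower number from compound 2 to compound 3 (0.09 log units; that floor lies within the scatter).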

Compound 3, half-maximal inhibitory concentration: 40900 nM
Estimate against measurement, compound 3: 1.0-fold (0.01 log units) below, and the stated range covers the measured number.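

In this assay, the halogen swap reads as an at least 1.2-fold lower number from compound 2 to compound 3 (0.08 log units; that floor lies within the scatter), so no advantage of chloro over fluoro at this place can be claimed. Replacing nitro with chloro gives a 10-fold higher number from compound 1 to compound 3 (1.02 log units; beyond the scatter), which shows that a second halogen, like fluoro, also ends up far weaker than compound 1. Compound 2 gives a limit rather than a number, so the halogen step has only a floor and its true size cannot be read: the limit of > 50000 nM in this assay, at which 1 of the 3 values shown sits.

The compounds shown do not settle whether the stronger inhibition of compound 1 is specific to nitro, and a nitrile, a trifluoromethyl or a carboxylic acid on the same aromatic carbon would test this. Going by these compounds, whether bromo or methoxy at this place would stay with the halogens or move towards compound 1 also remains open.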